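Trimming the Benzodioxin Arm of Compound 2

The source may report more compounds than this note shows. Statements on the series, on what has been measured and on what is new or still open speak of the compounds shown alone.

Measured so far: compound 1 `CC(C)(C)c1ccc(CNCCNS(=O)(=O)c2cc(C(F)(F)F)cc(C(F)(F)F)c2)cc1` gives 13000 nM in a functional assay on Capan-2 cells (Homo sapiens) for inhibition, read by MTT assay, with a stated time of 72 h; a higher number here means a weaker inhibitor of growth, a lower number a stronger inhibitor of growth; compound 2 `O=S(=O)(NCCCNCC1COc2ccccc2O1)c1cc(C(F)(F)F)cc(C(F)(F)F)c1` gives 2500 nM; compound 3 `O=S(=O)(NCCNCc1cccc2ccccc12)c1cc(C(F)(F)F)cc(C(F)(F)F)c1` gives 21000 nM.

Compound 2 stands at the lowest of these three numbers; compound 1 is the nearest to it and compound 3 the furthest, and both gaps lie beyond the scatter. Compound 4 `O=S(=O)(NCCCNCc1ccccc1)c1cc(C(F)(F)F)cc(C(F)(F)F)c1` differs from compound 2 in one place: phenyl in place of 2,3-dihydro-1,4-benzodioxin-2-yl on a saturated chain carbon bound to an amine nitrogen. Going by the values given here, no measured pair swaps this group directly. Among the compounds with values here, the only measured step, a 1.6-fold higher number from compound 1 to compound 3 (0.21 log units; within the scatter), exchanges one aryl group for another on the same kind of carbon and stays within the scatter, but it occurs in the pair whose numbers sit well above that of compound 2. The group that leaves carries two hydrogen-bond acceptors and a second ring, and nothing arriving replaces them, so a move back towards the higher numbers of compound 1 and compound 3 is the expectation. Compound 4 is therefore estimated at 6000 nM, ranging from 2500 nM to 15000 nM, a step of a 2.4-fold higher number from compound 2 to compound 4 (0.38 log units; beyond the scatter) expected towards weaker growth inhibition.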

Compound 4, concentration for 50% growth inhibition: 14000 nM
Compound 4: middle estimate off by 2.3-fold (0.37 log units), on the low side; the measured number falls inside the stated range.
By their numbers in this assay, from the lowest: compound 2; then compounds 1, 4 and 3 (each within the scatter of the next).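

In this assay, putting phenyl in place of 2,3-dihydro-1,4-benzodioxin-2-yl gives a 5.6-fold higher number from compound 2 to compound 4 (0.75 log units; beyond the scatter), so this change on a saturated chain carbon bound to an amine nitrogen moves the number beyond the scatter. The earlier exchange of one aryl group for another, a 1.6-fold higher number from compound 1 to compound 3 (0.21 log units; within the scatter), stayed within the scatter and gave no sign that this place responds to what it carries. The group that leaves in compound 4 takes with it a six-membered non-aromatic ring with 2 hetero atoms and 2 hydrogen-bond acceptors, while one six-membered aromatic ring of carbon only remains.

No evidence is available on what lies behind this step. On these data alone, whether a methoxy group on the phenyl of compound 4, or a tetrahydropyran-2-yl group in its place, would restore the number of compound 2 remains open.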